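Lengthening the Sulfonyl Chain of Compound 1

The source may report more compounds than this note shows. Statements on the series, on what has been measured and on what is new or still open speak of the compounds shown alone.

Compound 1 `CCCCS(=O)(=O)c1ccc(O)c(C(=O)Nc2ccc(Br)cc2)c1`: 5.2
Compound 2 `CCCCS(=O)(=O)c1ccc(O)c(C(=O)Nc2ccc(C(F)(F)F)cc2)c1`: 6.2
Compound 3 `CCCCCCS(=O)(=O)c1ccc(O)c(C(=O)Nc2ccc(C(F)(F)F)cc2)c1`: 6.2

In a physicochemical assay for acid dissociation, compound 1 stands lowest of the three measured numbers. The nearest is compound 2, reached by a number 1.00 log units higher from compound 1 to compound 2 (beyond the scatter). Compound 3 gives 6.2, the same digits as compound 2.

Compound 4 `CCCCCCCCCCCCS(=O)(=O)c1ccc(O)c(C(=O)Nc2ccc(Br)cc2)c1` differs from compound 1 by octyl in place of hydrogen on a saturated chain carbon, four bonds along the chain from a sulfonyl sulfur. Within the data shown here, the one step that bears on this is the chain lengthening at the same place, no change at the digits printed from compound 2 to compound 3 (within the scatter), which stayed within the scatter. On that basis the step of no change at the digits printed from compound 1 to compound 4 (within the scatter) is expected to fall within the scatter. Compound 4 is therefore estimated at 5.2, in a range from 4.9 to 5.5.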

Compound 4, acid dissociation constant: 5.2
The estimate for compound 4 equals the measured number at the digits printed; the measured number falls inside the stated range.
By their numbers in this assay, from the lowest: compounds 1 and 4 (each within the scatter of the next); then compounds 2 and 3 (each within the scatter of the next).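

In this assay, octyl in place of hydrogen on a saturated chain carbon, four bonds along the chain from a sulfonyl sulfur, gives no change at the digits printed from compound 1 to compound 4 (within the scatter). This position therefore now shows no step beyond the scatter for either chain addition: ethyl with trifluoromethyl on the aromatic carbon, and the larger octyl with bromo there. Nothing available here explains this result. On these data alone, whether a carboxylic acid or an amine at this position would leave the number unchanged remains open.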